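A Second Hydroxyl on the Amide Side Chain

A few compounds are considered here, and "the series" means these few. Any claim that something is new, unique, unknown or untested is made for them only; others in the source may bear on it.

Compound 1 `CCC(CC)(c1ccc(OCC(=O)C(C)(C)C)c(C)c1)c1ccc(C(=O)NCCC(=O)OC)n1C`: 790 nM in an assay on HL-60 cells for agonist activity at vitamin D3 receptor (Homo sapiens), with a stated time of 96 h; a lower number here means that less compound is needed, a higher number that more compound is needed for the effect
Compound 2 `CCn1c(C(=O)NCC(=O)OC)ccc1C(CC)(CC)c1ccc(OCC(=O)C(C)(C)C)c(C)c1`: 1830 nM in this assay
Compound 3 `CCC(CC)(c1ccc(OCC(O)C(C)(C)C)c(C)c1)c1ccc(C(=O)NCCCO)n1C`: 150 nM in this assay

Of these three, compound 3 gives the lowest number in this assay; its gaps to compound 1 and to compound 2 both lie beyond the usual scatter, so it is the most potent of the measured set. Compound 4 `CCC(CC)(c1ccc(OCC(O)C(C)(C)C)c(C)c1)c1ccc(C(=O)N[C@H](CO)CCO)n1C` differs from compound 3 in one place: hydroxymethyl in place of hydrogen on a saturated chain carbon bound to an amide-type nitrogen and a saturated chain carbon. Within the data shown here, no pair of measured compounds shows this exact change, so no measured step guides it. The added group is small and carries one donor and one acceptor. For compound 4 a step no larger than the scatter is expected, no change at the digits printed from compound 3 to compound 4 (within the scatter), and its value in this assay is estimated at 150 nM, between 50 nM and 500 nM.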

Compound 4, half-maximal effective concentration: 200 nM
For compound 4 the middle estimate is 1.3-fold (0.12 log units) below the measured one, and the stated range covers the measured number.
By their numbers in this assay, from the lowest: compounds 3 and 4 (each within the scatter of the next); then compound 1; then compound 2.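

In this assay hydroxymethyl in place of hydrogen gives a 1.3-fold higher number from compound 3 to compound 4 (0.12 log units; within the scatter) on the saturated chain carbon bound to an amide-type nitrogen and a saturated chain carbon. Among these compounds, this is the first measured step at this position, and it shows that 3-hydroxypropyl can become 3-hydroxy-1-(hydroxymethyl)propyl with no change beyond the scatter. Nothing available explains why the number holds.

As far as these compounds go, whether the same carbon would tolerate an aminomethyl group, a carboxylic acid or a longer chain stays open. So does the result for the mirror-image form of compound 4.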